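Swapping one group on the carbonyl of compound 2

The source may hold more compounds than are shown below. What is called first, only, known or untested is meant among the compounds shown, and "the series" means these compounds.

Measured so far in an ADME assay on microsomes from liver (Homo sapiens) for metabolic stability, with a stated time of 10 min (on this read-out higher numbers stand for a more stable compound and lower numbers for a less stable compound), are three compounds:
- compound 1 `O=C(O)[C@H]1CC[C@](F)(C(=O)N2CC[C@](c3ccc(C(F)(C(F)(F)F)C(F)(F)F)cc3)(S(=O)(=O)c3ccc(F)cc3)C2)CC1` with "not determined" (no result reported)
- compound 2 `NC(=O)[C@H]1CC[C@H](C(=O)N2CC[C@](c3ccc(C(F)(C(F)(F)F)C(F)(F)F)cc3)(S(=O)(=O)c3ccc(F)cc3)C2)CC1` with 100%
- compound 3 `CS(=O)(=O)C1CCC(C(=O)N2CC[C@](c3ccc(C(F)(C(F)(F)F)C(F)(F)F)cc3)(S(=O)(=O)c3ccc(F)cc3)C2)CC1` with 88%; 100% (2 entries)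

Among the compounds with values here, compound 2 stands at 100% as the only single number in this small set, while compound 1 has no result and compound 3 has more than one entry (the several entries of compound 3 in this assay, 88%; 100% (2 entries)).

Within the data shown here, compound 4 `O=C(N1CC[C@](c2ccc(C(F)(C(F)(F)F)C(F)(F)F)cc2)(S(=O)(=O)c2ccc(F)cc2)C1)C1(CO)CCS(=O)(=O)CC1` has no measurement yet. It keeps the rest of compound 2 unchanged and differs on a carbonyl carbon, where 4-(hydroxymethyl)-1,1-dioxothian-4-yl stands in place of 4-carbamoylcyclohexyl (4-(hydroxymethyl)-1,1-dioxothian-4-yl in place of 4-carbamoylcyclohexyl on a carbonyl carbon). Among the measured compounds shown here, no pair of measured compounds shows a change of this kind, and no measured compound carries the entering group, so the expectation has little to lean on.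

Compound 3 also carries another group on that carbonyl carbon and still gives 88%; 100% (2 entries) in this assay as its result, so a large loss is not expected. The estimated change is a number 8 percentage points lower from compound 2 to compound 4 (within the scatter) and so a small fall, no larger than the usual scatter. The expected range stays wide on the low side for that reason. Compound 4 is expected at 92% within an estimated range from 75% to 100% once it is measured.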

Compound 4, percent of the compound remaining: 75%
Estimate against measurement, compound 4: 17 percentage points above; measured number inside the range.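

The change on this carbonyl carbon now has a measured size in this assay, with a number 25 percentage points lower from compound 2 to compound 4 (beyond the scatter), so the position is not indifferent to the group it carries. Within the data shown here, until now the only other group with numbers at this carbon had given high entries, which gave no sign of such a fall: the several entries of compound 3 in this assay, 88%; 100% (2 entries) The step itself replaces a six-membered ring of carbon only with one holding a hetero atom, and it also exchanges the carbamoyl group for a hydroxymethyl group, so this single comparison does not show which part of the change goes with the lower number.

What the compounds shown leave open is whether the 1,1-dioxothian ring or the hydroxymethyl group on it accounts for the difference, as no compound here carries one without the other. They also leave open how a group such as an amine or a nitrile on the six-membered ring would stand in this assay against the carbamoyl group of compound 2.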